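Methyl in Place of Dichlorophenyl on the Shared Core

This account rests on a few compounds, and the source may have more. Where it says the series, first, only, none or still open, it means among the compounds named here.

Of the compounds shown here, two have been measured in an assay on isolated protein for positive allosteric modulation of Neuronal acetylcholine receptor; alpha4/beta2 (Homo sapiens); on this read-out lower numbers stand for an effect already at smaller amounts and higher numbers for an effect only at larger amounts of compound. Compound 2 `Clc1cccc(Cl)c1-c1cc(-c2cnn(C3CCNCC3)c2)on1` gives 410 nM, and compound 1 `Fc1cccc(-c2cc(-c3cnn(C4CCNCC4)c3)on2)c1Cl` gives 230 nM; the step of a 1.8-fold higher number from compound 1 to compound 2 (0.25 log units; within the scatter) lies within the scatter, so the two cannot be told apart. Compound 3 `Cc1cc(-c2cnn(C3CCNCC3)c2)on1` differs from compound 2 by methyl in place of 2,6-dichlorophenyl on an aromatic carbon. Going by the values given here, no measured step bears directly on this change: the only step known exchanges one aryl group for another and stays within the scatter, while here the aryl group is lost altogether. A move toward higher numbers is therefore expected, of uncertain size, as a 7.3-fold higher number from compound 2 to compound 3 (0.86 log units; beyond the scatter). Compound 3 is estimated at 3000 nM, with a range from 800 nM to 15000 nM.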

Compound 3, half-maximal effective concentration: 1300 nM
The estimate for compound 3 lay 2.3-fold (0.36 log units) above the measured number; the measured number falls inside the stated range.
By their numbers in this assay, from the lowest: compounds 1 and 2 (each within the scatter of the next); then compound 3.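

Replacing the aryl group with methyl at this position, rather than exchanging one aryl group for another, gives a 3.2-fold higher number from compound 2 to compound 3 (0.50 log units; beyond the scatter) and a 5.7-fold higher number from compound 1 to compound 3 (0.75 log units; beyond the scatter), so in this assay the loss of the ring can be told apart from the scatter. Even so, the effect persists without any aryl group, with compound 3 at 1300 nM. Nothing available accounts for this shift. The compounds shown leave open how an unsubstituted phenyl would compare with the chlorinated aryl groups. They also leave open whether a longer chain, such as propyl, would fall nearer methyl or the aryl groups.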